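A few compounds are considered here, and "the series" means these few. Any claim that something is new, unique, unknown or untested is made for them only; others in the source may bear on it.

Compound 1 `Cn1c(-c2ccccc2Br)cnc1NC(=O)c1ccc(F)cc1` — in a toxicity assay on THP-1 cells (Homo sapiens) for inhibition (a lower number here means that less compound is tolerated, a higher number that more compound is tolerated), compound 1 gives only a limit, > 100000 nM.
Compound 2 `Cn1c(-c2ccc(F)cc2)cnc1NC(=O)c1ccc(F)cc1` — in this assay compound 2 likewise gives only a limit, > 100000 nM.
Compound 3 `COc1ccc(-c2cnc(NC(=O)C3CCOCC3)n2C)cc1` — in this assay compound 3 also gives only a limit, > 100000 nM.

Among the measured compounds shown here, the one measured step, a step that the two limits leave unreadable from compound 1 to compound 2, cannot be read, since both of its ends are limits. Compound 3 stands where every value in this set stands: at the limit (the limit of > 100000 nM in this assay, at which 3 of the 3 values shown sit), so its placing in this assay is a ceiling rather than a number. The next compound, compound 4 `COc1ccc(-c2cnc(NC(=O)c3ccc(C#N)cc3)n2C)cc1`, differs from compound 3 in one place: 4-cyanophenyl in place of oxan-4-yl on a carbonyl carbon. For the measured compounds named here, no measured step touches this change, and the one step that exists is unreadable, so nothing in the data points to a direction. The expectation for compound 4 is therefore a step from compound 3 of no size beyond the scatter, a number no higher from compound 3 to compound 4 (the limit leaves the size open), with the outcome most likely another limit. Compound 4 is expected at about 100000 nM in this assay, with a range from 40000 nM to 300000 nM.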

Compound 4, half-maximal cytotoxic concentration: > 100000 nM
Compound 4: no number, only a limit; the forecaster's own chance of this, stated with the estimate: 85%; the middle value lies on the limit itself.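

Among the compounds shown here, compound 3 and compound 4 both give only a limit, so no step between them can be read. The compounds shown leave open whether 4-cyanophenyl in place of oxan-4-yl changes the half-maximal cytotoxic concentration in this assay at all, and all of them share one reading: the limit of > 100000 nM in this assay, at which 4 of the 4 values shown sit.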